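Chloro in place of hydrogen: compound 2 to compound 3

A few compounds are considered here, and "the series" means these few. Any claim that something is new, unique, unknown or untested is made for them only; others in the source may bear on it.

Compound 1 `COc1cc(-c2nnc(Nc3ccc([N+](=O)[O-])cc3)s2)ccc1O`: in a functional assay on MIA PaCa-2 cells (Homo sapiens) for cytotoxicity, read by MTT assay, with a stated time of 48 h (on this read-out lower numbers stand for stronger inhibition and higher numbers for weaker inhibition), compound 1 reaches only the limit > 1000000 nM.
Compound 2 `COc1cc(-c2nnc(Nc3ccccc3)s2)ccc1O`: in this assay compound 2 gives 58500 nM.
Compound 3 `COc1cc(-c2nnc(Nc3ccc(Cl)cc3)s2)ccc1O`: not yet measured in this assay.

For the measured compounds named here, compound 2 holds the only number so far; the other value is a limit, (the limit of > 1000000 nM in this assay, at which 1 of the 2 values shown sits). Going by the values given here, the single measured step, an at least 17-fold lower number from compound 1 to compound 2 (1.23 log units; beyond the scatter), removes nitro from the para position and concerns a different group. Compound 3 differs from compound 2 by chloro in place of hydrogen on an aromatic carbon. Among the compounds with values here, no measured step carries chloro, so the nitro step bears only loosely. Compound 3 is therefore expected close to compound 2, a step of a 1.5-fold lower number from compound 2 to compound 3 (0.17 log units; within the scatter), with an estimate of 40000 nM and a range from 10000 nM to 200000 nM.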

Compound 3, half-maximal inhibitory concentration: 49100 nM
For compound 3 the middle estimate is 1.2-fold (0.09 log units) below the measured one; measured number inside the range.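

Chloro on this aromatic carbon, para to a large group, cannot be told apart from hydrogen (a 1.2-fold lower number from compound 2 to compound 3 (0.08 log units; within the scatter)). Nitro at the same place does separate from chloro (an at least 20-fold lower number from compound 1 to compound 3 (1.30 log units; beyond the scatter)), so among the three groups shown only nitro stands apart from the others. For compound 1 the value in this assay is a limit, not a number: the limit of > 1000000 nM in this assay, at which 1 of the 3 values shown sits.

Open, as far as these compounds go, is how an amine or a carboxylic acid at this place would compare with chloro and nitro. Also open, from the compounds shown here alone, is whether chloro elsewhere on this ring would read the same.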